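The source may report more compounds than this note shows. Statements on the series, on what has been measured and on what is new or still open speak of the compounds shown alone.

Compounds measured so far:
- compound 1 `COc1ccccc1C1CC(c2cc3ccccc3o2)=NN1C(=O)c1ccncc1`: in an ADME assay on Vero cells (Chlorocebus sabaeus) for cytotoxicity, read by MTT assay, with a stated time of 72 h (on this read-out lower numbers stand for stronger inhibition and higher numbers for weaker inhibition), compound 1 gives > 202000 nM, which is a limit of the assay rather than a number.
- compound 2 `O=C(c1ccncc1)N1N=C(c2cc3ccccc3o2)CC1c1ccc(Cl)cc1`: in this assay compound 2 gives > 220000 nM, also a limit.
- compound 3 `CCn1cc(C(=O)N2N=C(c3cc4ccccc4o3)CC2c2ccccc2O)c(=O)c2ccc(C)nc21`: in this assay compound 3 gives > 157000 nM, again a limit.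

Compound 3 therefore stands at a limit, as do the other two values shown, so no order among the three can be read. Among the measured compounds shown here, the only measured single-point step, a step that the two limits leave unreadable from compound 1 to compound 2, swaps the aryl group on the saturated ring carbon and is unreadable from the two limits. The change now followed, (3-nitrophenyl in place of 2-hydroxyphenyl on a saturated ring carbon), gives compound 4 `CCn1cc(C(=O)N2N=C(c3cc4ccccc4o3)CC2c2cccc([N+](=O)[O-])c2)c(=O)c2ccc(C)nc21`. For the measured compounds named here, the one comparable step bears on it but gives no readable size, so no step beyond the scatter is expected; the step from compound 3 to compound 4 is estimated as a step that the limit leaves unreadable from compound 3 to compound 4. Compound 4 is expected to give about 200000 nM, between 80000 nM and 500000 nM, most likely reported again as a limit.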

Compound 4, half-maximal inhibitory concentration: > 164000 nM
Compound 4: only a limit was reported; the forecaster's own chance of this, stated with the estimate: 80%; the middle value lies beyond the limit too.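

In this assay, among the compounds shown here, compound 3 and compound 4 both stand at limits, so no step between them can be read. The compounds shown leave open whether any swap of the aryl group on the saturated ring carbon changes cytotoxicity at all.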